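The source may report more compounds than this note shows. Statements on the series, on what has been measured and on what is new or still open speak of the compounds shown alone.

Measured compounds:
compound 1 `Cc1ccc(/C=C/C(=O)Oc2ccc(/C=C3\CCCCC3=O)cc2)cc1` gives 156000 nM in a functional assay on MOLT-4 cells (Homo sapiens); on this read-out higher numbers stand for weaker inhibition and lower numbers for stronger inhibition;
compound 2 `COc1ccc(/C=C/C(=O)Oc2ccc(/C=C3\CCCCC3=O)cc2)cc1` gives 2060 nM;
compound 3 `Cc1ccc(/C=C/C(=O)Oc2ccc(/C=C3\CCCC(CN(C)C)C3=O)cc2)cc1` gives 3390 nM.

Compound 3 stands second highest of the three numbers. Its nearest neighbour is compound 2, whose value sits within the scatter of compound 3; its furthest is compound 1, from which compound 3 is separated by a 46-fold lower number from compound 1 to compound 3 (1.66 log units; beyond the scatter).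

Compound 4 `CN(C)CC1CCC/C(=C\c2ccc(OC(=O)c3ccc(Cl)cc3)cc2)C1=O` arises from compound 3 by 4-chlorophenyl in place of 2-(4-methylphenyl)ethenyl on a carbonyl carbon. Neither measured step touches this part of the structure: a 76-fold lower number from compound 1 to compound 2 (1.88 log units; beyond the scatter) concerns the aromatic carbon substituent and a 46-fold lower number from compound 1 to compound 3 (1.66 log units; beyond the scatter) the saturated ring, so nothing here bears directly on an exchange at the carbonyl carbon. The estimate is therefore anchored at compound 3 and assumes a step no larger than the scatter, expressed as a 1.0-fold higher number from compound 3 to compound 4 (0.01 log units; within the scatter). Compound 4 is expected to give 3500 nM, within 800 nM to 15000 nM.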

Compound 4, half-maximal inhibitory concentration: 5110 nM
For compound 4 the middle estimate is 1.5-fold (0.16 log units) below the measured one; the measured number falls inside the stated range.
By their numbers in this assay, from the lowest: compounds 2, 3 and 4 (each within the scatter of the next, the first and the last beyond it); then compound 1.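

At this carbonyl carbon, 4-chlorophenyl in place of 2-(4-methylphenyl)ethenyl gives a 1.5-fold higher number from compound 3 to compound 4 (0.18 log units; within the scatter) in this assay. Going by these compounds alone, the earlier compounds all carry the 2-(4-methylphenyl)ethenyl or its methoxy counterpart, so only this pair shows that the values of compound 3 and compound 4 stay within the scatter when the group goes from 9 heavy atoms to 7 and loses its double bond. No measurement at hand offers an explanation for this result. From the compounds shown here alone, it remains open how a carboxylic acid or an amine on the aromatic ring of this group would read, and whether the same exchange would read alike on the core of compound 1, which lacks the (dimethylamino)methyl group.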